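This account rests on a few compounds, and the source may have more. Where it says the series, first, only, none or still open, it means among the compounds named here.

Measured in an in vitro ADME assay on microsomes from Gut (Homo sapiens) for metabolic stability, using NADPH; on this read-out lower numbers stand for slow clearance and higher numbers for fast clearance:

- compound 1 `COc1ccc(Cl)cc1Cn1c(C(=O)NCC(C)(C)CO)cc2cc(C#N)ccc21`: < 6 mL.min-1.g-1 (a limit, not a number)
- compound 2 `COc1ccc(Br)cc1Cn1c(C(=O)NCC(C)(C)CO)cc2cc(C#N)ccc21`: < 6 mL.min-1.g-1 (a limit, not a number)
- compound 3 `Cc1ccc(C)c(Cn2c(C(=O)NCC(C)(C)CO)cc3cc(C#N)ccc32)c1`: < 6 mL.min-1.g-1 (a limit, not a number)

Compound 2 has no exact value, and it stands with compound 1 and compound 3 at the limit of < 6 mL.min-1.g-1 in this assay, at which 3 of the 3 values shown sit. The next compound, compound 4 `COc1ccc(Br)cc1Cn1c(C(=O)NCCCO)cc2cc(C#N)ccc21`, keeps everything in compound 2 except one group: 2-hydroxyethyl in place of 1-(hydroxymethyl)-1-methylethyl on a saturated chain carbon bound to an amide-type nitrogen. Cut one bond further out, this is 2-(hydroxymethyl)-2-methylpropyl changing to 3-hydroxypropyl.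

Three measured steps connect the known compounds: a step that the two limits leave unreadable from compound 1 to compound 2, a step that the two limits leave unreadable from compound 1 to compound 3 and a step that the two limits leave unreadable from compound 2 to compound 3. None of them changes the group at this place, and none has a readable size, so they offer no direct guide to this change. Going by the values given here, they show only that the other changes tried so far all left this assay reading the same limit. With so little to go on, no shift beyond the usual scatter is expected, and compound 4 may well be reported only as a limit too.

The expected change is a step that the limit leaves unreadable from compound 2 to compound 4.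

For compound 4, the estimated value is 5 mL.min-1.g-1, with an expected range of 3 mL.min-1.g-1 to 10 mL.min-1.g-1.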

Compound 4, intrinsic clearance in microsomes: < 6 mL.min-1.g-1
Compound 4 ended at the assay's limit; the forecaster's own chance of this, stated with the estimate: 75%; the middle value is on the limit's open side.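

Compound 2 and compound 4 are both reported as limits rather than numbers, so no step can be read between them, because all the results sit at one value: the limit of < 6 mL.min-1.g-1 in this assay, at which 4 of the 4 values shown sit.

The compounds shown leave open how their clearances truly compare, and whether changing 2-(hydroxymethyl)-2-methylpropyl to 3-hydroxypropyl alters clearance at all.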